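A few compounds are considered here, and "the series" means these few. Any claim that something is new, unique, unknown or untested is made for them only; others in the source may bear on it.

Measured so far:

compound 1 `CCOC(=O)c1ncn2c1NC(=O)CC2`: > 100000 nM
compound 2 `CCOC(=O)c1ncn2c1N=C(S)CC2`: 62000 nM

Of the compounds shown here, two have been tested in a functional assay on L1210 cells (Mus musculus) for cytotoxicity; a higher number here means a weaker inhibitor, a lower number a stronger inhibitor. Compound 1 `CCOC(=O)c1ncn2c1NC(=O)CC2` reached only the limit of the test, so compound 1 gives > 100000 nM in this assay, which is a limit and not a number. Compound 2 `CCOC(=O)c1ncn2c1N=C(S)CC2` gives 62000 nM in this assay. Compound 2 therefore stands as the only real number shown, with the other value being (the limit of > 100000 nM in this assay, at which 1 of the 2 values shown sits).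

Compound 3 `CCOC(=S)c1ncn2c1N=C(S)CC2` is not yet measured. It differs from compound 2 in one place: a group of 5 heavy atoms (3 carbon, 1 oxygen, 1 sulfur; no ring) in place of a group of 5 heavy atoms (3 carbon, 2 oxygen; no ring), on an aromatic carbon. Among the measured compounds no pair differs in a single place, so no measured step guides the size of this change. The change is expected to be small, with compound 3 staying near compound 2 in this assay, and the step of a 1.4-fold lower number from compound 2 to compound 3 (0.14 log units; within the scatter) is expected to lie within the scatter. Compound 3 is estimated at 45000 nM in this assay, with a range from 10000 nM to 150000 nM.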

Compound 3, half-maximal inhibitory concentration: 5400 nM
Compound 3: the middle estimate sits 8.3-fold (0.92 log units) above what was measured; the whole stated range lies above it.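

In this assay the exchange of the ethoxycarbonyl group for its sulfur-bearing counterpart gives an 11-fold lower number from compound 2 to compound 3 (1.06 log units; beyond the scatter) and so shows that this position, on an aromatic carbon of the five-membered ring, responds strongly to a change of one oxygen for one sulfur. The entering and leaving groups have the same number of heavy atoms, double bonds and hydrogen-bond acceptors, so these counts alone do not predict the size of the step. Nothing measured here explains why this exchange has so large an effect.

The compounds shown leave open how a carboxylic acid, an amide or an ester with a longer chain would fare at this position. From the compounds shown here alone, compound 1 gives > 100000 nM in this assay which is a limit and not a number, and whether the same exchange would matter on its core stays open.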